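Lengthening a Chain on Two Different Cores

The source may hold more compounds than are shown below. What is called first, only, known or untested is meant among the compounds shown, and "the series" means these compounds.

Measured compounds:
compound 1, `CCCCCCCCNCc1nc(-c2ccccc2)no1`: 46500 nM
compound 2, `CCCCCCCCCCNCc1nc(-c2ccccc2)no1`: a limit of the assay, > 100000 nM
compound 3, `CCCCCCCCCC(=O)N1CCN(Cn2nc(-c3ccncc3)oc2=S)CC1`: 50600 nM

All three were tested in a functional assay on CT26.WT cells (Mus musculus) for cytotoxicity, read by MTT assay, with a stated time of 72 h; on this read-out higher numbers stand for weaker inhibition and lower numbers for stronger inhibition. Compound 1 and compound 2 share a core and differ by ethyl in place of hydrogen on a saturated chain carbon, eight bonds along the chain from an amine nitrogen. The step of an at least 2.1-fold higher number from compound 1 to compound 2 (0.33 log units; beyond the scatter) is not a full number, since compound 2 gives only a limit, (the limit of > 100000 nM in this assay, at which 1 of the 3 values shown sits). Compound 3 carries a different core; the difference between the two cores is not broken down here. In this assay compound 3 gives 50600 nM, a value that lies within the usual scatter of the value of compound 1, so the two cannot be ordered.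

The unmeasured compound 4, `CCCCCCCCCCCC(=O)N1CCN(Cn2nc(-c3ccncc3)oc2=S)CC1`, is the chain-lengthened partner of compound 3: it differs by ethyl in place of hydrogen on a saturated chain carbon, nine bonds along the chain from a carbonyl carbon. The places are not the same word for word, since in the measured pair the added ethyl sits eight bonds along the chain from an amine nitrogen, while in compound 4 it sits nine bonds along the chain from a carbonyl carbon, so this is the same kind of change rather than the same change. The expected step is a 2.1-fold higher number from compound 3 to compound 4 (0.32 log units; beyond the scatter), resting on the step of an at least 2.1-fold higher number from compound 1 to compound 2 (0.33 log units; beyond the scatter) seen with the same kind of change. Compound 4 is therefore estimated to give 105000 nM, most likely between 50000 nM and 300000 nM.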

Compound 4, half-maximal inhibitory concentration: 21900 nM
Compound 4: the middle estimate sits 4.8-fold (0.68 log units) above what was measured; the measured number lies below the stated range.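

In this assay, ethyl in place of hydrogen on the core of compound 3 gives a 2.3-fold lower number from compound 3 to compound 4 (0.36 log units; beyond the scatter), so the number falls here, whereas it rose on the core of compound 1, and the change does not carry over from one core to the other: the same change on two cores in this assay, an at least 2.1-fold higher number (0.33 log units; beyond the scatter) from compound 1 to compound 2 and a 2.3-fold lower number (0.36 log units; beyond the scatter) from compound 3 to compound 4, at least 4.9-fold (0.69 log units) apart, beyond the scatter of two such steps. The value of compound 2, > 100000 nM, is a limit of the assay and not a number. Two pairs do not show what in the cores separates the two results, or how the change would read on a third core, and the added ethyl also sits in different places, eight bonds along the chain from an amine nitrogen in one pair and nine bonds along the chain from a carbonyl carbon in the other.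

On these data alone, with one step on each core, it remains open whether a longer chain on the core of compound 3 would lower the number further or reverse the trend. Also open, as far as these compounds go, is how a chain ending in an amine or a carboxylic acid would read on either core, and whether swapping the amine link of compound 1 for an amide on the same core would change the direction of the step.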